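This account rests on a few compounds, and the source may have more. Where it says the series, first, only, none or still open, it means among the compounds named here.

Of the compounds shown here, three of one series have been measured in a functional assay on the whole organism for inhibition, with Chlorella vulgaris as the target, read by spectrophotometry, with a stated time of 4 h; on this read-out higher numbers stand for weaker inhibition and lower numbers for stronger inhibition. Compound 1 `CC(C)(C)c1cnc(C(=O)Nc2cccc(O)c2)cn1` gives 329000 nM in this assay, compound 2 `CCCc1cnc(C(=O)/C=C/c2ccc(O)cc2)cn1` gives 514000 nM, and compound 3 `CC(C)c1cnc(C(=O)/C=C/c2ccccc2O)cn1` gives 78000 nM. Compound 2 and compound 1 lie within the usual scatter of each other, so nothing separates them; compound 3, by contrast, gives a number far enough below that of compound 2 to lie beyond the scatter.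

The step under consideration leads from compound 2 to compound 4 `CCCCc1cnc(C(=O)/C=C/c2ccc(O)cc2)cn1`, which is not yet measured. The structural difference is methyl in place of hydrogen on a saturated chain carbon, three bonds along the chain from an aromatic carbon; read one bond further out, propyl becomes butyl.

Among the measured compounds shown here, no measured pair of compounds in this set differs in just this way, so no measured step guides the expectation. Lengthening a chain by one carbon at the end is a small change, and no step beyond the scatter is expected in either direction. Compound 4 is therefore estimated to give 400000 nM in this assay, within a range from 150000 nM to 1000000 nM. The expected step from compound 2 to compound 4 is a 1.3-fold lower number from compound 2 to compound 4 (0.11 log units; within the scatter), essentially no change beyond the scatter.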

Compound 4, half-maximal inhibitory concentration: 265000 nM
Beside the measured number, compound 4's estimate is 1.5-fold (0.18 log units) above it; measured number inside the range.
By their numbers in this assay, from the lowest: compound 3; then compounds 4, 1 and 2 (each within the scatter of the next).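

In this assay, among the compounds shown here, this is the first step that can be read between two compounds differing in one place: methyl in place of hydrogen on a saturated chain carbon, three bonds along the chain from an aromatic carbon, turns propyl into butyl and gives (a 1.9-fold lower number from compound 2 to compound 4 (0.29 log units; within the scatter)). At this position, therefore, the change from propyl to butyl does not separate compound 4 from compound 2, and this single pair gives no sign that the one added carbon matters here. No measurement at hand offers any explanation for this result.

As far as these compounds go, whether a longer chain such as hexyl, or an amine at the end of the chain, would stay within the scatter of compound 4 remains open. So does whether the same change would read alike on the core of compound 1.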